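The compounds below may be only part of what the source reports. "The series", "measured", "known", "first", "only" and "open" are said of these compounds alone.

Three compounds share one core and differ in the group attached through an oxygen on a saturated carbon and in the ketone side chain. In an assay on HEK293 cells for positive allosteric modulation of metabotropic glutamate receptor 2 (Rattus norvegicus), read by thallium flux, with a stated time of 2.5 min (on this read-out lower numbers stand for an effect already at smaller amounts and higher numbers for an effect only at larger amounts of compound), compound 1 `Cc1c(OCCCCOc2cccc(C(=O)O)c2)ccc(C(=O)CC(C)C)c1O` gives 222 nM, compound 2 `Cc1c(OCCCCOc2ccc(F)c(C(=O)O)c2)ccc(C(=O)CC(C)(C)C)c1O` gives 208 nM and compound 3 `Cc1cc(C(=O)O)ccc1OCCCCOc1ccc(C(=O)CC(C)C)c(O)c1C` gives 192 nM. Compound 3 has the lowest of the three numbers, yet both gaps to it lie within the scatter. Compound 4 `Cc1c(OCCCCOc2ccc(F)c(C(=O)O)c2)ccc(C(=O)CC(C)C)c1O` carries 3-carboxy-4-fluorophenyl in place of 4-carboxy-2-methylphenyl on an oxygen on a saturated carbon. For the measured compounds named here, the one measured change of this group, a 1.2-fold lower number from compound 1 to compound 3 (0.06 log units; within the scatter), stayed within the scatter, and compound 2, which already carries 3-carboxy-4-fluorophenyl, sits close to compound 1 and compound 3. For a 1.1-fold higher number from compound 3 to compound 4 (0.03 log units; within the scatter) no step beyond the scatter is therefore expected. Compound 4 is estimated at 205 nM, with a range from 100 nM to 420 nM.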

Compound 4, half-maximal effective concentration: 153 nM
Compound 4: the middle estimate sits 1.3-fold (0.13 log units) above what was measured, within the range that was stated.
By their numbers in this assay, from the lowest: compounds 4, 3, 2 and 1 (each within the scatter of the next).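

Changing the group at this position, on an oxygen on a saturated carbon, gave only a small shift: 3-carboxy-4-fluorophenyl in place of 4-carboxy-2-methylphenyl gives (a 1.3-fold lower number from compound 3 to compound 4 (0.10 log units; within the scatter)). The two other single changes also stay within the scatter: hydrogen in place of methyl on the ketone side chain (a 1.4-fold lower number from compound 2 to compound 4 (0.13 log units; within the scatter)) and fluoro in place of hydrogen on an aromatic carbon (a 1.5-fold lower number from compound 1 to compound 4 (0.16 log units; within the scatter)). No supporting measurement bears on these small steps.

On these data alone, every compound here carries a carboxylic acid on this ring, so the effect of an amide or a nitrile there stays open.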